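The source may report more compounds than this note shows. Statements on the series, on what has been measured and on what is new or still open speak of the compounds shown alone.

Measured compounds: compound 1 `CO[C@H]1CC[C@H](NC(=O)c2n[nH]cc2NC(=O)c2c(C)nc3ccccn23)CC1` with 34000 nM; compound 2 `COc1cccc(OC)c1C(=O)Nc1c[nH]nc1C(=O)NC1CC2CCC1C2` with > 50000 nM.

Of the compounds shown here, two have been measured in an ADME assay on MRC5 cells (Homo sapiens) for inhibition, with a stated time of 72 h; on this read-out lower numbers stand for an effect already at smaller amounts and higher numbers for an effect only at larger amounts of compound. Compound 1 gives a number in this assay, 34000 nM. For compound 2 the read-out in this assay is a limit of the assay, > 50000 nM, and not a number. Compound 2 thus stands at the limit of > 50000 nM in this assay, at which 1 of the 2 values shown sits, and no exact value is known for it.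

Compound 3 `COc1cccc(OC)c1C(=O)Nc1c[nH]nc1C(=O)NCC1CCCCC1` has not yet been measured. It differs from compound 2 in one place: a group of 7 heavy atoms (7 carbon; one six-membered non-aromatic ring of carbon only) in place of a group of 7 heavy atoms (7 carbon; 2 five-membered non-aromatic rings of carbon only), on an amide-type nitrogen. For the measured compounds named here, no step between two measured compounds is available, and the value of compound 2 is itself a limit, so the size of this change cannot be read from the data. The step that the limit leaves unreadable from compound 2 to compound 3 in this assay is expected to be small, within the usual scatter, with no definite direction. Compound 3 is estimated at 60000 nM in this assay, with a range from 25000 nM to 150000 nM, and a report of only a limit remains likely.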

Compound 3, half-maximal effective concentration: > 50000 nM
Compound 3: no number, only a limit; the forecaster's own chance of this, stated with the estimate: 70%; the middle value does not contradict the limit.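

In this assay, for the compounds shown here, compound 3, like compound 2, gives only a limit and not a number, and no step between the two can be read: the limit of > 50000 nM in this assay, at which 2 of the 3 values shown sit. The compounds shown leave open whether cyclohexylmethyl on the amide-type nitrogen changes the read-out at all.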